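Three Inactive Analogues and a Chloro Swap

A few compounds are considered here, and "the series" means these few. Any claim that something is new, unique, unknown or untested is made for them only; others in the source may bear on it.

All three compounds measured here share one core and differ in the substituent on the saturated chain carbon bound to an aromatic nitrogen. Compound 1 `N#Cc1ccccc1Cn1c(=O)[nH]c2nccc(N3CCC[C@@H](N)C3)c21` carries a nitrile on a benzyl group. In an assay on isolated protein for inhibition of Dipeptidyl peptidase 9 (Homo sapiens), read by luminescence, with a stated time of 15 min (on this read-out lower numbers stand for stronger inhibition and higher numbers for weaker inhibition), compound 1 reaches only a limit of > 100000 nM. Compound 2 `Cn1c(=O)n(Cc2ccccc2C#N)c2c(N3CCC[C@@H](N)C3)cccc21` moves the ring nitrogen and keeps the same benzyl group. In this assay compound 2 likewise gives only a limit of > 100000 nM. Compound 3 `Cn1c(=O)n(Cc2cccc(C#N)c2)c2c(N3CCC[C@@H](N)C3)ccnc21` places the nitrile at a different position of the benzyl ring. In this assay compound 3 also stops at a limit of > 100000 nM. So compound 3 stands where every measured compound stands: at the limit of > 100000 nM in this assay, at which 3 of the 3 values shown sit, with no numerical value to rank against.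

Compound 4 `Cn1c(=O)n(Cc2ccccc2Cl)c2c(N3CCC[C@@H](N)C3)ccnc21` is the next analogue. The change is 2-chlorophenyl in place of 3-cyanophenyl on a saturated chain carbon bound to an aromatic nitrogen. No measured pair separates a single change of this kind, so nothing shown tells how much such a swap can move the read-out. With all three measured compounds at the limit, the expectation for compound 4 in this assay is again a result at or near the limit, with the step that the limit leaves unreadable from compound 3 to compound 4 expected to be none beyond the scatter. The estimate for compound 4 is 150000 nM, ranging from 30000 nM to 1000000 nM.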

Compound 4, half-maximal inhibitory concentration: > 100000 nM
Compound 4: no number, only a limit; the forecaster's own chance of this, stated with the estimate: 75%; the middle value lies beyond the limit too.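

Compound 3 and compound 4 both stop at a limit rather than a number, so no step can be read for 2-chlorophenyl in place of 3-cyanophenyl. Which change, if any, would give a real number in this assay stays open, and so does how far any single swap can move the read-out.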